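A few compounds are considered here, and "the series" means these few. Any claim that something is new, unique, unknown or untested is made for them only; others in the source may bear on it.

Measured compounds:
compound 1 `Cc1ccc(C(=O)Nc2sc3c(c2C(N)=O)CCCC3)s1`, 652 nM
compound 2 `Cc1ccc(C(=O)Nc2sc3c(c2C(N)=O)CCOC3)s1`, 778 nM
compound 3 `CC1(C)Cc2c(sc(NC(=O)c3ccn[nH]3)c2C(N)=O)C(C)(C)O1`, 3 nM

In an assay on cells for positive allosteric modulation of Cystic fibrosis transmembrane conductance regulator variant F508del (Homo sapiens), with stated times of 10 min and 7 s, in the presence of a further agent that is not named here (a lower number here means that less compound is needed, a higher number that more compound is needed for the effect), compound 3 has the lowest of the three numbers, far below compound 1 and compound 2, and the gaps to both are beyond the usual scatter. Compound 4 `CC1(C)Cc2c(sc(NC(=O)C(C)(C)CO)c2C(N)=O)C(C)(C)O1` keeps the core of compound 3 and differs in one place: 1-(hydroxymethyl)-1-methylethyl in place of 1H-pyrazol-5-yl on a carbonyl carbon. Within the data shown here, no pair of measured compounds shows this kind of change, so the expected size of the step rests on compound 3 alone. For compound 4 the number in this assay is expected to rise, with a step from compound 3 to compound 4 of a 13-fold higher number from compound 3 to compound 4 (1.12 log units; beyond the scatter), most likely beyond the scatter. Compound 4 is estimated at 40 nM, with a plausible range from 5 nM to 400 nM.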

Compound 4, half-maximal effective concentration: 75 nM
The estimate for compound 4 lay 1.9-fold (0.27 log units) below the measured number; the measured number falls inside the stated range.
By their numbers in this assay, from the lowest: compound 3; then compound 4; then compounds 1 and 2 (each within the scatter of the next).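

On the shared core, the group on the carbonyl carbon strongly affects the number in this assay: 1-(hydroxymethyl)-1-methylethyl in place of 1H-pyrazol-5-yl gives a 25-fold higher number from compound 3 to compound 4 (1.40 log units; beyond the scatter). The two groups have the same heavy-atom, donor and acceptor counts, so these counts alone do not set the number; they differ in that only 1H-pyrazol-5-yl has a ring. No measurement here explains the step.

On these data alone, whether the ring itself matters remains open. A pyridine ring, a cyclopentyl ring, a carboxylic acid or a longer chain at this place could help separate these possibilities.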